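The source may report more compounds than this note shows. Statements on the series, on what has been measured and on what is new or still open speak of the compounds shown alone.

Working notes on the series. Two compounds have numbers in a functional assay on CHO cells for agonist activity at Free fatty acid receptor 2 (Homo sapiens), read by cAMP accumulation; on this read-out higher numbers stand for weaker inhibition and lower numbers for stronger inhibition. Compound 1 `CC(C)[C@H](C(=O)Nc1ncc[nH]1)c1ccc(Cl)cc1` gives 20000 nM in this assay. Compound 2 `CC(C)(C)[C@H](C(=O)Nc1ncc(F)s1)c1ccc(Cl)cc1` gives 700 nM in this assay; this is the lowest of the two numbers, and the nearest value, that of compound 1, stands beyond the scatter, so compound 2 is the more potent of the pair on what is shown. Compound 3 `CN1CCN(c2cnc(NC(=O)[C@H](c3ccc(Cl)cc3)C(C)(C)C)s2)CC1` has not yet been measured in this assay. Compound 3 differs from compound 2 in one place: 4-methylpiperazin-1-yl in place of fluoro on an aromatic carbon. Among the compounds with values here, no step between two measured compounds covers this kind of exchange, so the direction rests on judgement alone. The expectation is a step from compound 2 to compound 3 of a 1.4-fold lower number from compound 2 to compound 3 (0.15 log units; within the scatter), which may well stay within the scatter. For compound 3 the estimate in this assay is 500 nM, within a range from 100 nM to 3000 nM.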

Compound 3, half-maximal inhibitory concentration: 3800 nM
Estimate against measurement, compound 3: 7.6-fold (0.88 log units) below, and the stated range ends below it.
By their numbers in this assay, from the lowest: compound 2; then compound 3; then compound 1.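

In this assay the series gains its first exchange read at a single place: on the aromatic carbon next to the ring sulfur, 4-methylpiperazin-1-yl in place of fluoro gives a 5.4-fold higher number from compound 2 to compound 3 (0.73 log units; beyond the scatter) as a modest step beyond the scatter. This place therefore accepts a group of 7 heavy atoms carrying a six-membered non-aromatic ring while the number remains a measured value, though inhibition is weaker than with fluoro. Nothing measured on these compounds speaks to the cause of this step.

A single exchange cannot separate the contribution of the piperazine ring, that of its N-methyl group and the removal of fluoro. Hydrogen, chloro, morpholine or unsubstituted piperazine on the same carbon would bear directly on that question.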